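Removing One Chloro Group from a Fused Core

A few compounds are considered here, and "the series" means these few. Any claim that something is new, unique, unknown or untested is made for them only; others in the source may bear on it.

Measured so far:
compound 1 `ClCc1ccccc1Cn1cnc2c(Cl)nc(Cl)nc21`: 3090 nM
compound 2 `ClCc1ccccc1Cn1cnc2c(Cl)ncnc21`: 9330 nM
compound 3 `ClCc1ccc(Cn2cnc3nc(Cl)nc(Cl)c32)cc1`: 5370 nM

All three compounds were tested in a functional assay on CAKI-1 cells (Homo sapiens) for cytotoxicity, read by sulforhodamine B assay, with a stated time of 48 h; a lower number here means that less compound is tolerated, a higher number that more compound is tolerated. Compound 1 and compound 2 share a core and differ only by hydrogen in place of chloro on an aromatic carbon; this change produced a 3.0-fold higher number from compound 1 to compound 2 (0.48 log units; beyond the scatter). Compound 3 carries a core built from the same atoms as that of compound 1, but the difference between the two cores is not broken down here. In this assay compound 3 sits within the usual scatter of both compound 2 and compound 1, so no order among them can be claimed.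

Compound 4 `ClCc1ccc(Cn2cnc3ncnc(Cl)c32)cc1` has not yet been measured. It differs from compound 3 by hydrogen in place of chloro on an aromatic carbon, which is the same change, at the same place, as that from compound 1 to compound 2. Because a 3.0-fold higher number from compound 1 to compound 2 (0.48 log units; beyond the scatter) was seen for that change, a step of similar size is expected here, namely a 2.8-fold higher number from compound 3 to compound 4 (0.45 log units; beyond the scatter). This expectation rests on a single earlier example and is therefore uncertain. Compound 4 is estimated at 15000 nM, likely falling between 7000 nM and 35000 nM.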

Compound 4, concentration lethal to 50% of the cells: 9770 nM
Beside the measured number, compound 4's estimate is 1.5-fold (0.19 log units) above it, and the stated range covers the measured number.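

In this assay, putting hydrogen in place of chloro on this second core gives a 1.8-fold higher number from compound 3 to compound 4 (0.26 log units; within the scatter), so on its own this step cannot be told apart from the ordinary spread of repeated measurements. Set beside the earlier example, the two steps do not differ by more than that spread allows: the same change on two cores in this assay, a 3.0-fold higher number (0.48 log units; beyond the scatter) from compound 1 to compound 2 and a 1.8-fold higher number (0.26 log units; within the scatter) from compound 3 to compound 4, 1.7-fold (0.22 log units) apart, within the scatter of two such steps. The change therefore shows no sign of behaving differently on these two cores, but this does not prove that its size is the same on both, and two pairs say nothing about any other core in the series.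

The compounds shown leave open what a group other than hydrogen, such as an amine or a methoxy group, would do at this place between two ring nitrogen atoms. Also open, from the compounds shown here alone, is how the numbers would respond if a plain methyl group stood in place of the chloromethyl group that all four compounds carry.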